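Chloro for methyl on the shared core of compound 2

The source may report more compounds than this note shows. Statements on the series, on what has been measured and on what is new or still open speak of the compounds shown alone.

Measured so far:
compound 1 `Cc1ccc(NC(=O)c2cc(Oc3ccc(S(C)(=O)=O)cc3)cc(OC(C)C)c2)nc1` gives 17 mL/min/kg
compound 2 `Cc1cnc(-c2cc(Oc3ccc(S(C)(=O)=O)cc3)cc(OC(C)C)c2)[nH]c1=O` gives < 8 mL/min/kg

In an ADME assay on microsomes from liver (Homo sapiens) for metabolic stability (on this read-out lower numbers stand for slow clearance and higher numbers for fast clearance), compound 1 gives 17 mL/min/kg. For compound 2 the read-out is a limit of the assay and not a number: compound 2 stands at the limit of < 8 mL/min/kg in this assay, at which 1 of the 2 values shown sits. Among the compounds with values here, the one measured step, an at least 2.1-fold lower number from compound 1 to compound 2 (0.32 log units; beyond the scatter), goes from compound 1 down to the limit, so compound 2 is at the low end of what this assay reports and sits at least modestly lower than compound 1.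

Compound 3 `CC(C)Oc1cc(Oc2ccc(S(C)(=O)=O)cc2)cc(-c2ncc(Cl)c(=O)[nH]2)c1` is not yet measured. It differs from compound 2 in one place: chloro in place of methyl on an aromatic carbon. Within the data shown here, no measured step touches this change, so the only anchor is the value of compound 2, which is itself a limit. A step from compound 2 to compound 3 of no more than the usual scatter is expected in this assay, in either direction; the estimate for compound 3 is 7 mL/min/kg, with a range from 4 mL/min/kg to 14 mL/min/kg, and the step this implies is a step that the limit leaves unreadable from compound 2 to compound 3. A further limit for compound 3 is as likely as a number.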

Compound 3, clearance: < 8 mL/min/kg
Compound 3: only a limit was reported; the forecaster's own chance of this, stated with the estimate: 55%; the middle value lies beyond the limit too.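

In this assay compound 3 gives < 8 mL/min/kg, which is a limit of the assay and not a number. Chloro in place of methyl, on this aromatic carbon para to a large group, therefore leaves the read-out at the low end of what the assay reports, and the step between the two compounds cannot be read, with the compounds shown now standing at that end as follows: the limit of < 8 mL/min/kg in this assay, at which 2 of the 3 values shown sit.

Within the data shown here, the one new step that can be read is an at least 2.1-fold lower number from compound 1 to compound 3 (0.32 log units; beyond the scatter), so the lower number seen on replacing the group on the aromatic carbon in compound 1 holds with chloro as well as with methyl on the new ring.

From the compounds shown here alone, how far compound 2 and compound 3 lie under the limit stays open, and so does any order between them in this assay. Also open, going by these compounds, is whether a larger group at this position, such as ethyl, methoxy or trifluoromethyl, would bring the read-out back to a measurable number.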